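Cytotoxicity of a Methylphenyl Amide Variant Held at the Limit

The source may report more compounds than this note shows. Statements on the series, on what has been measured and on what is new or still open speak of the compounds shown alone.

Three measured compounds share one core and differ only in the group on the amide-type nitrogen in the ring. Compound 1 `COc1ccc([C@H]2CC(=O)N(Cc3cccc(N)c3)C2)cc1OC1CCCC1` reaches the limit of a functional assay on HEK293 cells (Homo sapiens) for cytotoxicity (a lower number here means that less compound is tolerated, a higher number that more compound is tolerated), and gives > 10000 nM there. Compound 2 `COc1ccc([C@H]2CC(=O)N(c3cccc(N(C)C)c3)C2)cc1OC1CCCC1` likewise gives only the limit > 10000 nM in this assay. Compound 3 `COc1ccc([C@H]2CC(=O)N(c3ccccc3N)C2)cc1OC1CCCC1` also stops at the limit, > 10000 nM, in this assay. The steps a step that the two limits leave unreadable from compound 1 to compound 2, a step that the two limits leave unreadable from compound 1 to compound 3 and a step that the two limits leave unreadable from compound 2 to compound 3 are therefore all unreadable. Compound 4 `COc1ccc([C@H]2CC(=O)N(c3cccc(C)c3)C2)cc1OC1CCCC1` differs from compound 2 by methyl in place of dimethylamino on an aromatic carbon. Because the limit of > 10000 nM in this assay, at which 3 of the 3 values shown sit, covers every value shown, compound 4 is expected to sit at the same limit, with an expected step that the limit leaves unreadable from compound 2 to compound 4. Compound 4 is estimated at 15000 nM, within 7000 nM to 40000 nM.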

Compound 4, half-maximal cytotoxic concentration: > 10000 nM
Compound 4: only a limit was reported; the forecaster's own chance of this, stated with the estimate: 85%; the middle value does not contradict the limit.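

Compound 4 gives > 10000 nM in this assay, which is a limit, so no step from compound 1, compound 2 or compound 3 to compound 4 can be read: the limit of > 10000 nM in this assay, at which 4 of the 4 values shown sit.

The compounds shown leave open whether any group on the amide-type nitrogen in the ring would give a number rather than a limit in this assay.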